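Phenyl replaces a chain end in compound 4

The source may hold more compounds than are shown below. What is called first, only, known or untested is meant among the compounds shown, and "the series" means these compounds.

Results in a functional assay on MCF7 cells (Homo sapiens) for inhibition, read by fluorescence, with a stated time of 72 h (on this read-out higher numbers stand for weaker inhibition of growth and lower numbers for stronger inhibition of growth), so far
- compound 1 `CC(C)=CCn1cnc2c(Nc3cccc(Cl)c3)nc(N[C@H]3CC[C@H](N)CC3)nc21` gives 4200 nM
- compound 2 `CCCCn1cnc2c(NCc3cccc(Cl)c3)nc(N[C@H]3CC[C@H](N)CC3)nc21` gives 2200 nM
- compound 3 `CC(C)CCn1cnc2c(NCc3cccc(Cl)c3)nc(N[C@H]3CC[C@H](N)CC3)nc21` gives 4700 nM

Compound 1 at 4200 nM lies within the scatter of both compound 2 and compound 3, although those two differ beyond it.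

Compound 4 `N[C@H]1CC[C@H](Nc2nc(Nc3cccc(Cl)c3)c3ncn(Cc4ccccc4)c3n2)CC1` has phenyl in place of 2-methylprop-1-en-1-yl on a saturated chain carbon bound to an aromatic nitrogen. Going by the values given here, no measured compound carries phenyl there, so the evidence is indirect. Among the compounds with values here, the only measured chain change, a 2.1-fold higher number from compound 2 to compound 3 (0.33 log units; beyond the scatter), was modest, and compound 2 and compound 3 also differ from compound 1 elsewhere.

In this assay, the estimated step is a 1.2-fold lower number from compound 1 to compound 4 (0.08 log units; within the scatter), which is expected to stay within the scatter, with no firm direction. For compound 4 the expected value is 3500 nM with a range from 1200 nM to 10000 nM.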

Compound 4, concentration for 50% growth inhibition: 3600 nM
Estimate against measurement, compound 4: 1.0-fold (0.01 log units) below; the range from low to high includes it.
By their numbers in this assay, from the lowest: compounds 2, 4, 1 and 3 (each within the scatter of the next, the first and the last beyond it).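

In this assay, phenyl in place of 2-methylprop-1-en-1-yl on a saturated chain carbon bound to an aromatic nitrogen gives a 1.2-fold lower number from compound 1 to compound 4 (0.07 log units; within the scatter) and so leaves growth inhibition level. This position therefore accepts a six-membered aromatic ring of carbon only in place of a branched chain with a double bond, and benzyl serves as well as 3-methylbut-2-en-1-yl here. No measurement available here accounts for this result.

From the compounds shown here alone, whether a longer chain, or a carboxylic acid or an amine on the chain at this place, would give a similar number remains open.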